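Fluoroquinolone carboxylic acids: cytotoxicity notes for compound 4

The compounds below may be only part of what the source reports. "The series", "measured", "known", "first", "only" and "open" are said of these compounds alone.

Measured so far in a functional assay on V79 cells (Cricetulus griseus) for cytotoxicity, read by colony formation; a lower number here means a stronger inhibitor, a higher number a weaker inhibitor:
Compound 1, `CC1(N)CCN(c2c(F)cc3c(=O)c(C(=O)O)cn(C4CC4)c3c2C(F)(F)F)C1`, gives 110 ug/mL.
Compound 2, `CC1(N)CCN(c2c(F)cc3c(=O)c(C(=O)O)cn(-c4ccc(F)cc4F)c3c2C(F)(F)F)C1`, gives 18 ug/mL.
Compound 3, `CC1CN(c2c(F)cc3c(=O)c(C(=O)O)cn(C4CC4)c3c2Cl)CCN1`, gives 45 ug/mL.

Compounds 1 and 2 differ by 2,4-difluorophenyl in place of cyclopropyl on an aromatic nitrogen, and this gave a 6.1-fold lower number from compound 1 to compound 2 (0.79 log units; beyond the scatter). How the core of compound 3 differs from the core of compound 1 is not broken down here; the two values show compound 3 sitting at a lower number than compound 1.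

Compound 4, `CC1CN(c2c(F)cc3c(=O)c(C(=O)O)cn(-c4ccc(F)cc4F)c3c2Cl)CCN1`, is not yet measured. It differs from compound 3 by 2,4-difluorophenyl in place of cyclopropyl on an aromatic nitrogen, the same change as from compound 1 to compound 2. For compound 4 the expected step is a 5.6-fold lower number from compound 3 to compound 4 (0.75 log units; beyond the scatter), resting on a 6.1-fold lower number from compound 1 to compound 2 (0.79 log units; beyond the scatter), with some allowance for the different core. In this assay compound 4 is thus estimated at 8 ug/mL, most likely between 4 ug/mL and 18 ug/mL.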

Compound 4, half-maximal inhibitory concentration: > 500 ug/mL
Compound 4: a limit, no number; the forecaster's own chance of this, stated with the estimate: 5%; middle value at least 62-fold (1.79 log units) away from the limit.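

In this assay, 2,4-difluorophenyl in place of cyclopropyl on the aromatic nitrogen gives an at least 11-fold higher number from compound 3 to compound 4 (1.04 log units; beyond the scatter). Compound 4 gives > 500 ug/mL, which is a limit of the assay and not a number, so this step has a lower bound but no exact size. The change does not carry from one core to the other, even in direction, though two pairs cannot show which feature of the cores decides the outcome: the same change on two cores in this assay, a 6.1-fold lower number (0.79 log units; beyond the scatter) from compound 1 to compound 2 and an at least 11-fold higher number (1.04 log units; beyond the scatter) from compound 3 to compound 4, at least 67-fold (1.83 log units) apart, beyond the scatter of two such steps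

The compounds shown do not separate the trifluoromethyl group of compound 1 from the chlorine of compound 3 with the amine substituent held fixed. From the compounds shown here alone, whether an ethyl group on the aromatic nitrogen would follow either pair also remains open.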